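Swapping Chloro for Methyl on a Keto-Acid Scaffold

The source may report more compounds than this note shows. Statements on the series, on what has been measured and on what is new or still open speak of the compounds shown alone.

Compound 1: `O=C(O)C(=O)CC(=O)c1ccc(-c2ccccc2)cc1`, 3500 nM
Compound 2: `O=C(O)C(=O)CC(=O)c1ccccc1Cl`, 3510 nM

Of the compounds shown here, two have been measured in an assay on isolated protein for inhibition of Flap endonuclease 1 (Homo sapiens); a higher number here means a weaker inhibitor, a lower number a stronger inhibitor. Compound 1 gives 3500 nM, and compound 2 gives 3510 nM. The two numbers sit within the usual scatter of each other, so compound 2 stands level with compound 1; neither can be called the stronger or weaker inhibitor on this evidence.

The next compound, compound 3 `Cc1ccccc1C(=O)CC(=O)C(=O)O`, is not yet measured. It differs from compound 2 in one place: methyl in place of chloro on an aromatic carbon. Among the measured compounds shown here, no measured pair shows what such a swap does on this core, so the expectation rests only on the fact that both groups are small and sit in the same position. The expected step from compound 2 to compound 3 is a 1.0-fold lower number from compound 2 to compound 3 (0.00 log units; within the scatter), which means no change beyond the scatter. Compound 3 is therefore estimated at 3500 nM in this assay, with a range from 1500 nM to 8000 nM.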

Compound 3, half-maximal inhibitory concentration: 12900 nM
The estimate for compound 3 lay 3.7-fold (0.57 log units) below the measured number, outside the stated range (above it).
By their numbers in this assay, from the lowest: compounds 1 and 2 (each within the scatter of the next); then compound 3.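

In this assay, methyl in place of chloro brings a 3.7-fold higher number from compound 2 to compound 3 (0.57 log units; beyond the scatter), so this aromatic carbon, ortho to a group of 8 heavy atoms, does not treat these two groups alike, even though each counts one heavy atom and neither brings a ring, a hydrogen-bond donor or acceptor, or a charge. Since a higher number means a weaker inhibitor, chloro is the better of the two here, something compound 1 and compound 2 could not show, as they differ in more than one place. Nothing shown explains this difference.

On these data alone, with only these two groups at this position, it remains open whether chloro helps or methyl harms. Fluoro, bromo, methoxy or a plain hydrogen in the same place would help separate these possibilities.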